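The source may hold more compounds than are shown below. What is called first, only, known or untested is meant among the compounds shown, and "the series" means these compounds.

Compound 1 `CCCCNc1ccnc2cc(Cl)ccc12`: 11400 nM
Compound 2 `CCCCNc1ccnc2cc(F)ccc12`: 3700 nM

Both compounds were tested in a functional assay on MCF7 cells (Homo sapiens) for cytotoxicity, read by sulforhodamine B assay, with a stated time of 48 h, in the presence of a further agent that is not named here; on this read-out higher numbers stand for weaker inhibition of growth and lower numbers for stronger inhibition of growth. Compound 1 gives the higher of the two numbers, and its nearest neighbour is compound 2, reached by a 3.1-fold lower number from compound 1 to compound 2 (0.49 log units; beyond the scatter); that step swaps one halogen for another on the shared core and leaves the butyl chain untouched.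

Compound 3 `CN(C)CCNc1ccnc2cc(Cl)ccc12` keeps the chloro of compound 1 and alters the chain instead: dimethylamino in place of ethyl on a saturated chain carbon, two bonds along the chain from a nitrogen on an aromatic ring. Among the measured compounds shown here, the only measured step concerns the halogen on the core, not the chain, so nothing among the measured compounds speaks directly to this change. In the absence of a comparable step, the expectation for compound 3 in this assay is a number near that of compound 1, with a wide range that allows a shift in either direction. Compound 3 is therefore estimated at 9000 nM, between 2500 nM and 32000 nM. This estimate means an expected step of a 1.3-fold lower number from compound 1 to compound 3 (0.10 log units; within the scatter), which would sit within the usual scatter.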

Compound 3, concentration for 50% growth inhibition: 7370 nM
Compound 3: the middle estimate sits 1.2-fold (0.09 log units) above what was measured, and the stated range covers the measured number.
By their numbers in this assay, from the lowest: compounds 2, 3 and 1 (each within the scatter of the next, the first and the last beyond it).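

Among the compounds shown here, this is the first reading on the chain rather than on the halogen of the shared core. In this assay, placing dimethylamino on a saturated chain carbon, two bonds along the chain from a nitrogen on an aromatic ring, gives a 1.5-fold lower number from compound 1 to compound 3 (0.19 log units; within the scatter). Butyl therefore gives way to 2-(dimethylamino)ethyl, with one more heavy atom and one hydrogen-bond acceptor added, yet the two numbers cannot be told apart in this read-out, whereas the halogen step from the earlier compounds lay beyond the scatter. No supporting measurement is available to explain this result.

Going by these compounds, a single exchange at the chain cannot show whether the chain is generally open to change, so it remains unknown how a longer chain, a diethylamino group, a morpholine ring or a carboxylic acid at the same place would read in this assay. It also remains open whether 2-(dimethylamino)ethyl would read the same way on the fluoro core of compound 2, since the compounds shown carry this chain only with chloro on the core.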